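Swapping the phenoxy for a 4-methoxyphenyl group

The source may report more compounds than this note shows. Statements on the series, on what has been measured and on what is new or still open speak of the compounds shown alone.

In an ADME assay on HepG2 cells (Homo sapiens) for cytotoxicity, read by luminescence, CellTiter-Glo and ATP content, with a stated time of 72 h (on this read-out lower numbers stand for an effect already at smaller amounts and higher numbers for an effect only at larger amounts of compound), compound 3 `c1ccc(Oc2ccc3c(NCCCNCc4ccco4)ccnc3c2)cc1` gives 15200 nM, which puts it second highest among the three measured compounds. Compound 2 `c1ccc(CCc2ccc3c(NCCCNCc4ccco4)ccnc3c2)cc1` gives 16000 nM, and the two numbers lie within the scatter of each other, as the step of a 1.1-fold lower number from compound 2 to compound 3 (0.02 log units; within the scatter) shows. Compound 1 `Fc1ccc(-c2ccc3c(NCCCNCc4ccco4)ccnc3c2)cc1` gives 7760 nM; the step of a 2.0-fold higher number from compound 1 to compound 3 (0.29 log units; within the scatter) also stays within the scatter. Among the compounds with values here, only the step of a 2.1-fold higher number from compound 1 to compound 2 (0.31 log units; beyond the scatter) reaches just beyond it.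

Compound 4 `COc1ccc(-c2ccc3c(NCCCNCc4ccco4)ccnc3c2)cc1` differs from compound 3 in one place: 4-methoxyphenyl in place of phenoxy on an aromatic carbon. The closest guide is the step of a 2.0-fold higher number from compound 1 to compound 3 (0.29 log units; within the scatter), since compound 1 likewise bears a para-substituted phenyl group on that carbon and its number lies within the scatter of compound 3. A return toward the value of compound 1 is therefore possible, but no step beyond the scatter is expected. Compound 4 is expected to give 10000 nM in this assay, within a range of 4500 nM to 22000 nM, corresponding to an estimated step of a 1.5-fold lower number from compound 3 to compound 4 (0.18 log units; within the scatter).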

Compound 4, half-maximal effective concentration: 6000 nM
Estimate against measurement, compound 4: 1.7-fold (0.22 log units) above; low and high end bracket the measured number.
By their numbers in this assay, from the lowest: compounds 4, 1, 3 and 2 (each within the scatter of the next, the first and the last beyond it).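

With a phenyl group on this carbon carrying 4-methoxy, the change from phenoxy now gives a step beyond the scatter in this assay, with a 2.5-fold lower number from compound 3 to compound 4 (0.40 log units; beyond the scatter), and the change from phenethyl does likewise, with a 2.7-fold lower number from compound 2 to compound 4 (0.43 log units; beyond the scatter). The substituent on that phenyl ring makes no readable difference here, since methoxy in place of fluoro gives a 1.3-fold lower number from compound 1 to compound 4 (0.11 log units; within the scatter) and stays within the scatter. Compounds with a phenyl group directly on this carbon do not separate cleanly from the others, however, as compound 1 remains within the scatter of compound 3, and nothing shown gives a reason for these steps.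

On these data alone, whether an amine or a carboxylic acid on the same phenyl ring would move the number remains open. So does whether a longer chain in place of phenethyl would do so.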